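A few compounds are considered here, and "the series" means these few. Any claim that something is new, unique, unknown or untested is made for them only; others in the source may bear on it.

Working notes on the series. The measured compounds are compound 1 `Cc1c(OCC2=NCCN2)ccc(Cl)c1NS(C)(=O)=O`, compound 2 `Cc1ccc2c(c1NS(C)(=O)=O)CCC2c1ncc[nH]1` and compound 3 `CCS(=O)(=O)Nc1cccc2c1CCC2c1ncc[nH]1`. In a functional assay on CHO cells for agonist activity at Alpha-1A adrenergic receptor (Homo sapiens), read by FLIPR and calcium flux (on this read-out lower numbers stand for an effect already at smaller amounts and higher numbers for an effect only at larger amounts of compound), compound 1 gives 25 nM, compound 2 gives 33 nM and compound 3 gives 32 nM. Among these three numbers compound 3 sits second highest; its nearest neighbour is compound 2 and its furthest is compound 1, yet both gaps lie within the usual scatter, so the three values cannot be told apart. Among the compounds with values here, no pair of measured compounds differs in a single place, so no measured step is available to lean on.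

The next compound is compound 4 `c1cc(-c2ccn[nH]2)c2c(c1)C(c1ncc[nH]1)CC2`. It differs from compound 3 as follows: 1H-pyrazol-5-yl in place of (ethylsulfonyl)amino on an aromatic carbon. Within the data shown here, each of the three measured compounds carries a sulfonamide on the aromatic ring of its core, whereas compound 4 carries none, and the data hold no measured step for such an exchange. Among the measured compounds shown here, with a substituent of this kind removed for the first time, the expectation in this assay is a step of a 4.7-fold higher number from compound 3 to compound 4 (0.67 log units; beyond the scatter), toward a higher number and beyond the scatter. Compound 4 is estimated at 150 nM, with a range from 40 nM to 600 nM.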

Compound 4, half-maximal effective concentration: 52 nM
Beside the measured number, compound 4's estimate is 2.9-fold (0.46 log units) above it; low and high end bracket the measured number.
By their numbers in this assay, from the lowest: compounds 1, 3, 2 and 4 (each within the scatter of the next, the first and the last beyond it).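

In this assay the exchange of (ethylsulfonyl)amino for 1H-pyrazol-5-yl, on an aromatic carbon of the shared core, is a 1.6-fold higher number from compound 3 to compound 4 (0.21 log units; within the scatter) and so cannot be told apart from no change. The earlier compounds shown here all carried a sulfonamide on the aromatic ring and could not show this: at this position the sulfonamide can give way to a five-membered aromatic ring with no sulfur and no oxygen, and the read-out of compound 4 stays within the scatter of that of compound 3. Nothing measured here offers an explanation for why the two groups are not distinguished in this assay.

The compounds shown rest on this single exchange, so it remains open whether the tolerance at this position extends to groups of other kinds, such as a plain amine, a carboxylic acid or a simple phenyl ring. Going by these compounds, it also remains open whether the 1H-pyrazol-5-yl group would behave in the same way on the core of compound 2, which carries a methyl group on its aromatic ring.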